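Methoxy for Methyl in an Antiproliferative Series

The source may hold more compounds than are shown below. What is called first, only, known or untested is meant among the compounds shown, and "the series" means these compounds.

In a functional assay on Jurkat cells (Homo sapiens) for antiproliferative activity, read by MTT assay (a higher number here means a weaker inhibitor, a lower number a stronger inhibitor), compound 1 `COc1ccc(OC)c(/C=C2\CCc3cc(OC)c(OC)cc3C2=O)c1` gives 11000 nM and compound 2 `COc1cc2c(cc1OC)C(=O)/C(=C/c1cc(Cl)cc(Cl)c1)CC2` gives 7000 nM while compound 3 `COc1cc2c(cc1OC)C(=O)/C(=C/c1cccc(C)c1)C2` gives 1800 nM as the lowest of the three numbers, with both others higher beyond the scatter. Compound 4 `COc1cccc(/C=C2\Cc3cc(OC)c(OC)cc3C2=O)c1` has not yet been measured and differs from compound 3 by a single change methoxy in place of methyl on an aromatic carbon with methoxy in place of methyl on an aromatic carbon. Within the data shown here, no measured pair shows this change alone, so the expectation starts from compound 3 at 1800 nM as its anchor. The expected move is a 1.4-fold higher number from compound 3 to compound 4 (0.14 log units; within the scatter) and no step beyond the scatter is anticipated in this assay for this swap. For compound 4 the estimate is 2500 nM with an expected range from 900 nM to 8000 nM in repeated measurements.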

Compound 4, half-maximal inhibitory concentration: 12800 nM
For compound 4 the middle estimate is 5.1-fold (0.71 log units) below the measured one; the whole stated range lies below it.
By their numbers in this assay, from the lowest: compound 3; then compounds 2, 1 and 4 (each within the scatter of the next).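

On an aromatic carbon meta to a large group, the position is sensitive to this small swap: in this assay, methoxy in place of methyl gives a 7.1-fold higher number from compound 3 to compound 4 (0.85 log units; beyond the scatter), a step beyond the scatter. Among these compounds, this is the first single-change step, so it is the first direct reading of this position, and it favours methyl over methoxy here. Nothing available accounts for this step. As far as these compounds go, whether a hydroxyl, an amine or a fluorine on this carbon would track with methyl or with methoxy stays open. So does whether the same swap would give a similar step on the core of compound 1.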